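The source may report more compounds than this note shows. Statements on the series, on what has been measured and on what is new or still open speak of the compounds shown alone.

Measured compounds:
Compound 1 `CC(=O)Oc1ccccc1C1CC(C)=NN1C(=O)CN(C(C)C)C(C)C` — in a functional assay on PC-3 cells (Homo sapiens) for cytotoxicity, read by MTT assay, with a stated time of 48 h (a higher number here means a weaker inhibitor, a lower number a stronger inhibitor), compound 1 gives 24500 nM.
Compound 2 `O=C(c1ccccc1Cl)N1N=C(c2cc3ccccc3oc2=O)CC1c1ccccc1` — in this assay compound 2 gives 6370 nM.

Of these two numbers, compound 2 holds the lower one, and its gap to compound 1 lies beyond the scatter; the two compounds differ in many places at once, so their two values show only that and nothing about any single change.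

Compound 3 `O=C(CN1CCC(O)CC1)N1N=C(c2cc3ccccc3oc2=O)CC1c1ccccc1` is not yet measured. It follows from compound 2 by a single change: (4-hydroxypiperidin-1-yl)methyl in place of 2-chlorophenyl on a carbonyl carbon. Among the compounds with values here, no step between measured compounds isolates this change. Compound 1, which carries an aminomethyl carbonyl of its own, gives 24500 nM, and this is the only hint available. A step of modest size toward a higher number in this assay is expected, a 1.7-fold higher number from compound 2 to compound 3 (0.24 log units; within the scatter), though it may not exceed the scatter. Compound 3 is therefore estimated at 11000 nM, within 3500 nM to 35000 nM.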

Compound 3, half-maximal inhibitory concentration: "not active" (no number reported)
Nothing numeric was reported for compound 3; no gap can be computed for the estimate.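

In this assay, within the data shown here, compound 3 is reported as not active, without a number, so no step from compound 2 to compound 3 can be read. No evidence shown bears on this result. The compounds shown leave open what size of change (4-hydroxypiperidin-1-yl)methyl in place of 2-chlorophenyl brings on this carbonyl carbon.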